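Acetyl in place of methoxy on compound 3's aryl ring

This account rests on a few compounds, and the source may have more. Where it says the series, first, only, none or still open, it means among the compounds named here.

Three compounds have been measured in a functional assay on the whole organism for inhibition, with Rattus norvegicus as the target; on this read-out lower numbers stand for an effect already at smaller amounts and higher numbers for an effect only at larger amounts of compound:

Compound 1, `CC1CC/C(=N\Nc2cccc(Br)c2)c2ncc(C(=O)O)c(=O)n21`: 0.4 umol/kg
Compound 2, `CC1CC/C(=N\Nc2ccccc2O)c2ncc(C(=O)O)c(=O)n21`: 0.26 umol/kg
Compound 3, `COc1ccc(N/N=C2\CCC(C)n3c2ncc(C(=O)O)c3=O)cc1`: 0.8 umol/kg

Among these three numbers compound 3 has the highest. The two steps that lead to it are a 2.0-fold higher number from compound 1 to compound 3 (0.30 log units; within the scatter) and a 3.1-fold higher number from compound 2 to compound 3 (0.49 log units; beyond the scatter); the first stays within the scatter, the second is modest. Compound 1 and compound 2 differ from each other by a 1.5-fold lower number from compound 1 to compound 2 (0.19 log units; within the scatter), which is within the scatter.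

Compound 4, `CC(=O)c1ccc(N/N=C2\CCC(C)n3c2ncc(C(=O)O)c3=O)cc1`, is not yet measured. It differs from compound 3 in one place: acetyl in place of methoxy on an aromatic carbon. Both measured steps onto compound 3 replace the whole aryl group on the amine nitrogen, and neither changes a single group on an aromatic carbon or brings in acetyl, so they bear on this step only loosely. They show that such changes on this part of the molecule have moved the number by at most a modest amount. For compound 4 the step of no change at the digits printed from compound 3 to compound 4 (within the scatter) is therefore expected to stay within the scatter, with no clear direction. Compound 4 is estimated at 0.8 umol/kg, with a range from 0.3 umol/kg to 2.2 umol/kg.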

Compound 4, dose for 50% inhibition: 9.5 umol/kg
Compound 4: the middle estimate sits 12-fold (1.07 log units) below what was measured; measured number outside the range, above it.
By their numbers in this assay, from the lowest: compounds 2, 1 and 3 (each within the scatter of the next, the first and the last beyond it); then compound 4.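

For the compounds shown here, the step of a 12-fold higher number from compound 3 to compound 4 (1.07 log units; beyond the scatter) in this assay is large, and it shows that one group on an aromatic carbon, para to a large group, can shift the number further than the exchange of a whole aryl group did among the earlier compounds, where the widest step was a 3.1-fold higher number from compound 2 to compound 3 (0.49 log units; beyond the scatter). By the computed counts the change is small: acetyl brings one more carbon and a double bond outside aromatic rings, while the hydrogen-bond donors, the hydrogen-bond acceptors and the absence of net charge match those of methoxy. The position is therefore far less tolerant of this particular exchange than the earlier aryl changes suggested, yet no measurement shown here explains why the effect now needs so much more compound.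

The compounds shown leave open whether this shift belongs to acetyl alone or would also follow from a hydroxyl, an amine, a carboxylic acid or a longer chain such as propanoyl at the same place. They also leave open whether acetyl elsewhere on the aromatic ring would give a step of similar size.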